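The source may report more compounds than this note shows. Statements on the series, on what has been measured and on what is new or still open speak of the compounds shown alone.

Measured so far:
compound 1 `Nc1ccc(C(=O)/C=C/c2ccco2)cc1`, 38%
compound 2 `COc1ccc(/C=C/C(=O)c2ccc(NC(=O)C(C)O[N+](=O)[O-])cc2)cc1`, 46%

In a functional assay on the whole organism (strain albino) for inhibition, with Rattus norvegicus as the target, read by paw edema, with stated times of 30 min and 2 h, at a dose of 100 mg/kg by the oral route (a higher number here means more inhibition at the dose given (going by the name of the read-out), a lower number less inhibition), compound 2 gives 46%, the larger of the two numbers shown, while compound 1 gives 38%, a gap within the scatter, so the two are not told apart. Compound 3 `CC(O[N+](=O)[O-])C(=O)Nc1ccc(C(=O)/C=C/c2ccco2)cc1` differs from compound 2 by furan-2-yl in place of 4-methoxyphenyl on a double-bonded chain carbon bound to a double-bonded chain carbon. Among the compounds with values here, no pair of measured compounds differs in exactly this way, so the size of such a step is unknown; the expectation is for no step beyond the scatter in either direction. The step from compound 2 to compound 3 is estimated at a number 4 percentage points lower from compound 2 to compound 3 (within the scatter). Compound 3 is expected at 42%, with a range from 28% to 58%.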

Compound 3, a percentage reported as inhibition, in the whole organism at one dose (the size of the read-out at that dose, not a potency): 48%
The estimate for compound 3 lay 6 percentage points below the measured number, within the range that was stated.
By their numbers in this assay, from the lowest: compounds 1, 2 and 3 (each within the scatter of the next).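

In this assay, furan-2-yl in place of 4-methoxyphenyl on a double-bonded chain carbon bound to a double-bonded chain carbon gives a number 2 percentage points higher from compound 2 to compound 3 (within the scatter), so this place takes either ring without a step that stands out from the scatter. With furan-2-yl held fixed, the group of 8 heavy atoms in place of a hydrogen atom on a nitrogen on an aromatic ring gives a number 10 percentage points higher from compound 1 to compound 3 (within the scatter), so this change is not told apart from the scatter either. No measurement here bears on the cause of either step. From the compounds shown here alone, whether a thienyl or a pyridyl ring at this same place would give a step beyond the scatter stays open. Going by these compounds, with one dose per compound, potency also stays open.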